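Nitro in place of acetyl: a small step expected

The source may report more compounds than this note shows. Statements on the series, on what has been measured and on what is new or still open speak of the compounds shown alone.

Measured so far in a functional assay on HeLa cells (Homo sapiens) for antiproliferative activity, read by MTT assay, with a stated time of 72 h; on this read-out higher numbers stand for weaker inhibition and lower numbers for stronger inhibition
Compound 1 `Nc1nc(N)c2cc(CSC(=S)N3CCN(c4ccccc4)CC3)ccc2n1` gives 2840 nM
Compound 2 `Nc1nc(N)c2cc(CSC(=S)N3CCN(c4ccc(Cl)cc4)CC3)ccc2n1` gives 6990 nM
Compound 3 `CC(=O)c1ccc(N2CCN(C(=S)SCc3ccc4nc(N)nc(N)c4c3)CC2)cc1` gives 2040 nM

Two steps place compound 3 in this small set: a 1.4-fold lower number from compound 1 to compound 3 (0.14 log units; within the scatter) and a 3.4-fold lower number from compound 2 to compound 3 (0.53 log units; beyond the scatter) show it level with compound 1 and clear of compound 2. Compound 4 `Nc1nc(N)c2cc(CSC(=S)N3CCN(c4ccc([N+](=O)[O-])cc4)CC3)ccc2n1` has nitro in place of acetyl on an aromatic carbon with the rest unchanged. Among the measured compounds shown here, no measured compound carries nitro, so the only guide is what other changes at this place have done. There, a 2.5-fold higher number from compound 1 to compound 2 (0.39 log units; beyond the scatter) is modest, and the other steps are of similar or smaller size. The estimated step of a 1.5-fold higher number from compound 3 to compound 4 (0.17 log units; within the scatter) is therefore expected to stay within the scatter. Compound 4 is expected near 3000 nM with an estimated range from 1200 nM to 7500 nM in this assay terms.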

Compound 4, half-maximal inhibitory concentration: 1660 nM
Compound 4: the middle estimate sits 1.8-fold (0.26 log units) above what was measured; low and high end bracket the measured number.
By their numbers in this assay, from the lowest: compounds 4, 3 and 1 (each within the scatter of the next); then compound 2.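

In this assay, nitro proves interchangeable with acetyl on this aromatic carbon (a 1.2-fold lower number from compound 3 to compound 4 (0.09 log units; within the scatter)), and it also stays level with hydrogen there (a 1.7-fold lower number from compound 1 to compound 4 (0.23 log units; within the scatter)). Among the four groups, only chloro stands apart (a 4.2-fold lower number from compound 2 to compound 4 (0.62 log units; beyond the scatter)), so placing a group here does not in itself shift the number. Nothing available explains why chloro differs. Going by these compounds, it remains open whether an amine or a carboxylic acid on this carbon would stay level with hydrogen, acetyl and nitro or part from them as chloro does.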